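This account rests on a few compounds, and the source may have more. Where it says the series, first, only, none or still open, it means among the compounds named here.

Of the compounds shown here, two with the same core have been measured so far, and they differ only in the aromatic group attached to the five-membered ring of that core. Compound 1 `COc1ccc(-c2cnc(C(=O)CCCCCCc3ccccc3)o2)cc1` carries a 4-methoxyphenyl group, and in an assay (Rattus norvegicus) for inhibition of Fatty-acid amide hydrolase 1 (Homo sapiens) (a higher number here means a weaker inhibitor, a lower number a stronger inhibitor), compound 1 gives 100 nM. Compound 2 `Cc1cccc(-c2cnc(C(=O)CCCCCCc3ccccc3)o2)n1` carries a 6-methylpyridin-2-yl group instead, and in this assay compound 2 gives 3.3 nM. That single exchange produced a 30-fold lower number from compound 1 to compound 2 (1.48 log units; beyond the scatter), so compound 2 stands lowest of the two numbers measured.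

Compound 3 `O=C(CCCCCCc1ccccc1)c1ncc(-c2ncccn2)o1` has not yet been measured. It differs from compound 2 in one place: pyrimidin-2-yl in place of 6-methylpyridin-2-yl on an aromatic carbon. For the measured compounds named here, the only measured step that bears on this site is a 30-fold lower number from compound 1 to compound 2 (1.48 log units; beyond the scatter), which shows that a six-membered ring holding a nitrogen gave a far lower number than a ring without one. Going by the values given here, compound 3 keeps a ring nitrogen in that group, drops the methyl and adds a second nitrogen; no measured step covers those two changes. Because a 30-fold lower number from compound 1 to compound 2 (1.48 log units; beyond the scatter) rewarded the presence of a ring nitrogen, compound 3 is expected to stay close to compound 2, with a 1.5-fold higher number from compound 2 to compound 3 (0.18 log units; within the scatter) likely inside the scatter. In this assay compound 3 is therefore estimated at 5 nM, in a range from 1.5 nM to 20 nM.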

Compound 3, inhibition constant: 5.3 nM
Estimate against measurement, compound 3: 1.1-fold (0.03 log units) below; measured number inside the range.
By their numbers in this assay, from the lowest: compounds 2 and 3 (each within the scatter of the next); then compound 1.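

In this assay, pyrimidin-2-yl in place of 6-methylpyridin-2-yl gives a 1.6-fold higher number from compound 2 to compound 3 (0.21 log units; within the scatter) and so stays inside the usual scatter, which shows that on this aromatic carbon, next to the ring oxygen, the methyl group is not required for a low number. The step of a 19-fold lower number from compound 1 to compound 3 (1.28 log units; beyond the scatter) is large, so the advantage over 4-methoxyphenyl seen with compound 2 also appears with a second group, and among these three compounds both groups with ring nitrogens give far lower numbers than the ring without one. No measurement here explains why these groups behave alike or why they differ from 4-methoxyphenyl.

Compound 3 differs from compound 2 by both the methyl group and the second ring nitrogen, so the contribution of each remains unresolved, and an unsubstituted pyridin-2-yl group would help separate them. On these data alone, it also remains open how an unsubstituted phenyl ring would compare with these groups at this position, and whether the result would hold with a shorter chain between the carbonyl and the terminal phenyl ring.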